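Swapping phenyl for cyclohexyl on the amine nitrogen

The source may hold more compounds than are shown below. What is called first, only, known or untested is meant among the compounds shown, and "the series" means these compounds.

compound 1 `COc1cc(/C=C/C(=O)/C=C(\Nc2ccc(F)cc2)SC)cc(OC)c1OC`: 43400 nM
compound 2 `COc1cc(/C=C/C(=O)/C=C(\Nc2ccccc2)SC)cc(OC)c1OC`: 64600 nM

Both compounds were tested in an ADME assay on Vero cells (Chlorocebus sabaeus) for cytotoxicity, read by MTT assay, with a stated time of 72 h; a higher number here means that more compound is tolerated, a lower number that less compound is tolerated. They differ in one place, and the step of a 1.5-fold higher number from compound 1 to compound 2 (0.17 log units; within the scatter) is small. Among the measured compounds shown here, compound 2 thus stands with the higher of the two numbers in this assay, but its only neighbour, compound 1, lies within the scatter, so no order between them can be claimed.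

Compound 3 `COc1cc(/C=C/C(=O)/C=C(\NC2CCCCC2)SC)cc(OC)c1OC` differs from compound 2 by cyclohexyl in place of phenyl on an amine nitrogen. For the measured compounds named here, none of the measured steps touches this part of the molecule: the single step available concerns a fluoro on the other ring, and it was within the scatter. The data therefore give no ground for expecting a step in either direction beyond the scatter, and the uncertainty of the expectation is correspondingly wide. The expected step of a 1.1-fold lower number from compound 2 to compound 3 (0.03 log units; within the scatter) is essentially flat, with the range reflecting the lack of a guiding precedent. Compound 3 is accordingly estimated at 60000 nM, with a range from 20000 nM to 180000 nM.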

Compound 3, half-maximal cytotoxic concentration: 22700 nM
Compound 3: middle estimate off by 2.6-fold (0.42 log units), on the high side; the measured number falls inside the stated range.
By their numbers in this assay, from the lowest: compounds 3, 1 and 2 (each within the scatter of the next, the first and the last beyond it).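

In this assay, among the compounds shown here, the amine nitrogen emerges as a place where a change can register: cyclohexyl in place of phenyl gives a 2.8-fold lower number from compound 2 to compound 3 (0.45 log units; beyond the scatter), whereas the only earlier step, hydrogen in place of fluoro on an aromatic carbon, stayed within the scatter. The effect is not clear-cut, however, as cyclohexyl in place of 4-fluorophenyl gives a 1.9-fold lower number from compound 1 to compound 3 (0.28 log units; within the scatter), so compound 1 and compound 3 cannot be put in order, and only the comparison with compound 2 separates the non-aromatic ring from an aromatic one. Nothing available here accounts for the difference between the anilino and cyclohexylamino compounds.

What a cyclopentyl ring, a butyl chain or a benzyl group on this nitrogen would give remains open, so the compounds shown cannot tell whether the step from anilino to cyclohexylamino is specific to the six-membered carbon ring. As far as these compounds go, it is also open whether a methoxy group or a chlorine atom on the phenyl ring would separate from compound 2 in a way that fluoro did not.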